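Replacing pyrrolidine with methylimidazole in a carbamate

The source may hold more compounds than are shown below. What is called first, only, known or untested is meant among the compounds shown, and "the series" means these compounds.

Measured in a functional assay on the whole organism for agonist activity, with Mus musculus as the target; on this read-out lower numbers stand for an effect already at smaller amounts and higher numbers for an effect only at larger amounts of compound:
- Compound 1 `CC(=O)N(C)C(C)C#CCn1cncc1C`: > 100 mg/kg (a limit)
- Compound 2 `CCOC(=O)N(C)C(C)C#CCN1CCCC1`: > 100 mg/kg (a limit)

Compound 2 stands at a limit of this assay and not at a number, giving > 100 mg/kg. Compound 1 also gives only a limit, > 100 mg/kg. Among the compounds with values here, the record so far is therefore (the limit of > 100 mg/kg in this assay, at which 2 of the 2 values shown sit), and no measured step between compounds is available to size a change.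

Compound 3 `CCOC(=O)N(C)C(C)C#CCn1cncc1C` is still unmeasured and differs from compound 2 in one place: 5-methyl-1H-imidazol-1-yl in place of pyrrolidin-1-yl on a saturated chain carbon bound to a triple-bonded carbon. It has 5-methyl-1H-imidazol-1-yl in place of pyrrolidin-1-yl on a saturated chain carbon bound to a triple-bonded carbon.

In this assay, no step beyond the scatter is expected, and no direction is favoured. This expectation rests on compound 1, which already carries the 5-methyl-1H-imidazol-1-yl group and reaches only the limit > 100 mg/kg. The estimated change is a step that the limit leaves unreadable from compound 2 to compound 3, and it is rough since it starts from a limit. For compound 3 the estimated value is 120 mg/kg, with an expected range from 50 mg/kg to 300 mg/kg.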

Compound 3, dose for half-maximal effect: > 100 mg/kg
Compound 3: only a limit was reported; the forecaster's own chance of this, stated with the estimate: 75%; the middle value is on the limit's open side.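

No step can be read from compound 2 to compound 3 or from compound 1 to compound 3 in this assay, because all three compounds end at the same limit: the limit of > 100 mg/kg in this assay, at which 3 of the 3 values shown sit.

The compounds shown leave open whether either exchange, 5-methyl-1H-imidazol-1-yl for pyrrolidin-1-yl or ethoxy for methyl, shifts the read-out of this assay at all.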